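The source may hold more compounds than are shown below. What is called first, only, known or untested is meant among the compounds shown, and "the series" means these compounds.

Working notes on the series

Compound 1 `COc1ccc(Oc2ccc3c(NCCCNCc4cc(F)ccc4OC)ccnc3c2)cc1` and compound 2 `COc1ccc(Oc2ccc3c(NCCCNCc4cccc(OC)c4O)ccnc3c2)cc1` share one core and differ only at the outer aromatic ring on the saturated chain. In an ADME assay for permeability, using PAMPA, with a stated time of 30 min, at pH 7.4 (a lower number here means that the compound crosses the layer more slowly, a higher number that the compound crosses the layer faster), compound 1 gives 317 10^-6 cm/s, and compound 2 gives 317 10^-6 cm/s. The step of no change at the digits printed from compound 1 to compound 2 (within the scatter) shows that exchanging that outer ring leaves the read-out where it was; compound 1 therefore stands level with compound 2 and at the top of what has been measured so far.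

Compound 3 `COc1ccc(F)cc1CNCCCNc1ccnc2cc(Cc3cccc(C(F)(F)F)c3)ccc12` is the next case. Relative to compound 1 the change is 3-(trifluoromethyl)benzyl in place of 4-methoxyphenoxy on an aromatic carbon. For the measured compounds named here, no measured step touches this position: the only step known, from compound 1 to compound 2, is at the saturated chain end, and it was flat. It gives no direction for a change at the fused core, and the exchange here is of a different kind and size, as the counted difference shows. With nothing pointing to a move, the working expectation is a step of about a 1.1-fold lower number from compound 1 to compound 3 (0.02 log units; within the scatter), that is no change beyond the usual scatter. Compound 3 is accordingly expected to give around 300 10^-6 cm/s in this assay, with a range from 150 10^-6 cm/s to 500 10^-6 cm/s.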

Compound 3, apparent permeability: 23 10^-6 cm/s
Compound 3: the middle estimate sits 13-fold (1.12 log units) above what was measured; measured number below the stated range.
By their numbers in this assay, from the lowest: compound 3; then compounds 1 and 2 (each within the scatter of the next).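

For the compounds shown here, this position is the first place where this assay responds to a structural exchange: 3-(trifluoromethyl)benzyl in place of 4-methoxyphenoxy on the aromatic carbon gives a 14-fold lower number from compound 1 to compound 3 (1.14 log units; beyond the scatter), beyond the scatter, whereas the exchange at the outer ring on the saturated chain gave no change at the digits printed from compound 1 to compound 2 (within the scatter) as its only earlier step. The read-out therefore cannot be taken as insensitive to structure across the series, and the flat result at the chain end does not carry over to this aromatic carbon, which is meta to a fused ring and para to a fused ring. The exchange alters the linking atom and the substituent on the outer ring together, so this single step cannot assign the drop to either, and no supporting data bear on its cause.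

Still open, from the compounds shown here alone, is which part of the exchange carries the step: 4-methoxybenzyl or 3-(trifluoromethyl)phenoxy at the same carbon would separate the linking atom from the ring substituent. Also open, going by these compounds, is how a much smaller group there, such as a nitrile, would read, and whether the chain-end exchange stays flat with 3-(trifluoromethyl)benzyl in place.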